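Swapping Chloro for Bromo in a Histamine Antagonist Series

A few compounds are considered here, and "the series" means these few. Any claim that something is new, unique, unknown or untested is made for them only; others in the source may bear on it.

In a functional assay on ileum for antagonist activity at histamine H1 receptor (Cavia porcellus) (on this read-out higher numbers stand for weaker binding and lower numbers for tighter binding), compound 3 `N=C(NCCCc1c[nH]cn1)NCCC(c1ccc(Cl)cc1)c1ccccn1` gives 77.6 nM. Of the three measured compounds, compound 2 `N=C(NCCCc1c[nH]cn1)NCCC(c1ccccc1)c1ccccn1` gives 97.7 nM and compound 1 `N=C(NCCCc1c[nH]cn1)NCCCC(c1ccc(F)cc1)c1ccccn1` gives 46.8 nM, so compound 3 lies between the two, within the scatter of each. Within the data shown here, the one measured single change, a 1.3-fold lower number from compound 2 to compound 3 (0.10 log units; within the scatter), concerns the same place on the ring and stayed within the scatter. Compound 4 `N=C(NCCCc1c[nH]cn1)NCCC(c1ccc(Br)cc1)c1ccccn1` carries the change (bromo in place of chloro on an aromatic carbon), one halogen exchanged for another at that place. Because a 1.3-fold lower number from compound 2 to compound 3 (0.10 log units; within the scatter) stayed within the scatter, no step beyond the scatter is expected here: the estimated step is a 1.1-fold lower number from compound 3 to compound 4 (0.04 log units; within the scatter), and compound 4 is expected at 70 nM, between 35 nM and 140 nM.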

Compound 4, dissociation constant: 120 nM
Compound 4: the middle estimate sits 1.7-fold (0.23 log units) below what was measured; measured number inside the range.
By their numbers in this assay, from the lowest: compounds 1, 3, 2 and 4 (each within the scatter of the next, the first and the last beyond it).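

Bromo in place of chloro gives a 1.5-fold higher number from compound 3 to compound 4 (0.19 log units; within the scatter) in this assay and bromo in place of hydrogen gives a 1.2-fold higher number from compound 2 to compound 4 (0.09 log units; within the scatter) at the same place on the ring. Hydrogen, chloro and bromo at this place therefore all lie within the scatter of one another, so compound 2, compound 3 and compound 4 cannot be put in any order. No measurement available here speaks to why these numbers stay so close. On these data alone, what a group of another kind at this place, such as methoxy or an amine, would do to the number stays open.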